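A few compounds are considered here, and "the series" means these few. Any claim that something is new, unique, unknown or untested is made for them only; others in the source may bear on it.

In a functional assay on HepG2 cells (Homo sapiens) for antiproliferative activity, read by MTT assay, with a stated time of 48 h (a higher number here means a weaker inhibitor, a lower number a stronger inhibitor), compound 2 `COc1ccc(N(C)c2ccnc(Cl)n2)cc1O` gives 464 nM as the lowest numeric reading of the series, while compound 1 `COc1ccc(N(C)c2ccnc(Cl)n2)cc1[N+](=O)[O-]` gives 6120 nM in this assay as its reading. The nitro-to-hydroxy change is a 13-fold lower number from compound 1 to compound 2 (1.12 log units; beyond the scatter) on this scale. For compound 3 `COc1ccc(N(C)c2ccnc(Cl)n2)cc1OCCCCCBr` the reading > 10000 nM is a limit of the assay and not a number. Compound 4 `COc1ccc(N(C)c2ccnc(Cl)n2)cc1OCCC[Se]C#N` carries a group of 6 heavy atoms (4 carbon, 1 nitrogen, 1 selenium; no ring) in place of a hydrogen atom, on an oxygen on an aromatic ring in place of the hydrogen of compound 2. The only measured substitution on that oxygen is 5-bromopentyl, and an at least 21-fold higher number from compound 2 to compound 3 (1.33 log units; beyond the scatter) is a large step. With a different group entering, a smaller move in the same direction is expected. The estimated change is a 3.9-fold higher number from compound 2 to compound 4 (0.59 log units; beyond the scatter) for this step. The expected value for compound 4 is 1800 nM within an estimated range of 300 nM to 10000 nM in this assay for now.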

Compound 4, half-maximal inhibitory concentration: 5150 nM
Compound 4: middle estimate off by 2.9-fold (0.46 log units), on the low side; measured number inside the range.
By their numbers in this assay, from the lowest: compound 2; then compounds 4 and 1 (each within the scatter of the next). At a limit, above all of these: compound 3.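

Substitution on the oxygen on an aromatic ring now has a numeric size in this assay: the selenium-bearing chain gives an 11-fold higher number from compound 2 to compound 4 (1.05 log units; beyond the scatter), so the large rise no longer rests on a limit alone. Exchanging the nitro group for the selenium-bearing chain gives a 1.2-fold lower number from compound 1 to compound 4 (0.07 log units; within the scatter), a step that shows no difference. Exchanging the bromo chain for the selenium-bearing chain gives an at least 1.9-fold lower number from compound 3 to compound 4 (0.28 log units; that floor lies within the scatter). This step cannot be read as a size, because compound 3 stands at a limit: the limit of > 10000 nM in this assay, at which 1 of the 4 values shown sits.

Open, as far as these compounds go, is whether a methyl group, an amine or a carboxylic acid on that oxygen would stay near compound 2 at 464 nM. Also open, from the compounds shown here alone, is how chain length alone acts with the end group held fixed.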